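Working notes: cytotoxicity across compounds 1 to 3

The compounds below may be only part of what the source reports. "The series", "measured", "known", "first", "only" and "open" are said of these compounds alone.

Compound 1 `Cc1cn(C2CCN(Cc3cccc(OC4CCCC4)c3)CC2)c(=O)[nH]c1=O`: in an ADME assay on MRC5 cells (Homo sapiens) for cytotoxicity, read by fluorescence and resazurin assay, with a stated time of 3 days (a lower number here means a stronger inhibitor, a higher number a weaker inhibitor), compound 1 gives 30300 nM.
Compound 2 `Cc1cn(C2CCN(Cc3cccc(Oc4cc(F)cc(F)c4)c3)CC2)c(=O)[nH]c1=O`: in this assay compound 2 gives only an assay limit, > 64000 nM.

Compound 2 thus stands at the limit, as the limit of > 64000 nM in this assay, at which 1 of the 2 values shown sits, records, with no exact number. Among the measured compounds shown here, the step of an at least 2.1-fold higher number from compound 1 to compound 2 (0.32 log units; beyond the scatter) is the only measured change at this position. Compound 3 `Cc1cn(C2CCN(Cc3cccc(Oc4ccc(Cl)c(C(F)(F)F)c4)c3)CC2)c(=O)[nH]c1=O` differs from compound 2 by 4-chloro-3-(trifluoromethyl)phenyl in place of 3,5-difluorophenyl on an oxygen on an aromatic ring. With one measured step to go on, and that one ending at a limit, the expectation for compound 3 in this assay is an at least 1.1-fold lower number from compound 2 to compound 3 (0.06 log units; that floor lies within the scatter), no step beyond the scatter. Compound 3 is expected at 55000 nM, within 15000 nM to 150000 nM.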

Compound 3, half-maximal inhibitory concentration: 5280 nM
The estimate for compound 3 lay 10-fold (1.02 log units) above the measured number, and the stated range ends above it.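

In this assay, a phenyl group on this oxygen does not always raise the number: replacing 3,5-difluorophenyl with 4-chloro-3-(trifluoromethyl)phenyl gives an at least 12-fold lower number from compound 2 to compound 3 (1.08 log units; beyond the scatter). Against the cyclopentyl group, the new aryl group runs opposite to 3,5-difluorophenyl, with a 5.7-fold lower number from compound 1 to compound 3 (0.76 log units; beyond the scatter). The size of the first step is only a floor, as compound 2 is recorded at a limit: the limit of > 64000 nM in this assay, at which 1 of the 3 values shown sits.

The compounds shown do not separate the contribution of the chlorine from that of the trifluoromethyl group. Going by these compounds, how a phenyl ring carrying an amine or a carboxylic acid would read at this position remains open.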